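Bromo removal on the trimethoxybenzyl arm of compound 1

This account rests on a few compounds, and the source may have more. Where it says the series, first, only, none or still open, it means among the compounds named here.

Measured so far:
compound 1 `CCCCn1c(Cc2c(Br)c(OC)c(OC)c(OC)c2Br)nc2c(N)ncnc21` — 30200 nM
compound 2 `CC/C=C/Cn1c(Cc2cc(OC)c(OC)c(OC)c2)nc2c(N)ncnc21` — 46800 nM
compound 3 `CCn1c(Cc2cc(OC)c(OC)c(OC)c2)nc2c(N)ncnc21` — 79400 nM

In a functional assay on MCF7 cells (Homo sapiens) for antiproliferative activity (on this read-out lower numbers stand for stronger inhibition and higher numbers for weaker inhibition), compound 1 gives the lowest of the three numbers. The gap to compound 2 is within the scatter, and only compound 3 lies beyond it. Among the measured pairs, only one single-point step exists, on the chain at the aromatic nitrogen: a 1.7-fold higher number from compound 2 to compound 3 (0.23 log units; within the scatter). Among the measured compounds shown here, no measured pair covers a change on the benzyl ring alone, since compound 1 and compound 2 differ both in the chain and in the bromo groups.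

Compound 4 `CCCCn1c(Cc2cc(OC)c(OC)c(OC)c2Br)nc2c(N)ncnc21` is compound 1 with hydrogen in place of bromo on an aromatic carbon. Nothing measured speaks directly to this change, so the expectation for compound 4 in this assay rests on compound 1 alone, with a step of a 1.3-fold higher number from compound 1 to compound 4 (0.12 log units; within the scatter) that is expected to stay near the scatter in either direction. The estimated value for compound 4 is 40000 nM, with a range from 15000 nM to 120000 nM.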

Compound 4, half-maximal inhibitory concentration: 25100 nM
Compound 4: the middle estimate sits 1.6-fold (0.20 log units) above what was measured; the range from low to high includes it.
By their numbers in this assay, from the lowest: compounds 4, 1, 2 and 3 (each within the scatter of the next, the first and the last beyond it).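

In this assay, among the compounds shown here, a 1.2-fold lower number from compound 1 to compound 4 (0.08 log units; within the scatter) gives the first reading of a change on the benzyl ring alone, with the chain on the aromatic nitrogen held constant. At this aromatic carbon, ortho to a methoxy group and meta to the remaining bromo group, hydrogen can stand in place of bromo with the two numbers staying within the scatter of each other. No measurement at hand offers an explanation for this result.

The compounds shown leave open what the remaining bromo group contributes when this chain is kept, as the single step reads only one of the two bromo groups. Also open, going by these compounds, is how a chloro group, a nitrile or an amine on this aromatic carbon would read in this assay.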